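Replacing the amide amine of compound 1 with a phenyl ester

A few compounds are considered here, and "the series" means these few. Any claim that something is new, unique, unknown or untested is made for them only; others in the source may bear on it.

Measured compounds:
compound 1, `CCn1c(C(=O)NCCN)ccc1C(CC)(CC)c1ccc(OCC(=O)C(C)(C)C)c(C)c1`: 120 nM
compound 2, `CCOC(=O)CN(C)C(=O)c1ccc(C(CC)(CC)c2ccc(OCC(O)C(C)(C)C)c(C)c2)n1CC`: 210 nM
compound 3, `CCn1c(C(=O)NCCN)ccc1C(CC)(CC)c1ccc(OCC(O)C(C)(C)C)c(C)c1`: 10 nM

In an assay on HL-60 cells for agonist activity at vitamin D3 receptor (Homo sapiens), read by microscopy, with a stated time of 96 h (on this read-out lower numbers stand for an effect already at smaller amounts and higher numbers for an effect only at larger amounts of compound), compound 1 gives the second highest of the three numbers. Its nearest neighbour is compound 2, whose value lies within the scatter of it, and its furthest is compound 3, reached by a 12-fold lower number from compound 1 to compound 3 (1.08 log units; beyond the scatter). Compound 4, `CCOC(=O)c1ccc(OC(=O)c2ccc(C(CC)(CC)c3ccc(OCC(=O)C(C)(C)C)c(C)c3)n2CC)cc1`, is not yet measured. It differs from compound 1 in one place: 4-(ethoxycarbonyl)phenoxy in place of (2-aminoethyl)amino on a carbonyl carbon.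

The step that bears on this change is the one at the same carbonyl carbon, a 21-fold lower number from compound 2 to compound 3 (1.32 log units; beyond the scatter), which shows that the (2-aminoethyl)amino group goes with a much lower number than an ester-bearing amine. Compound 4 removes that group and brings in a larger ester-bearing group, so a step in the opposite direction, beyond the scatter, is expected in this assay. Compound 4 is therefore estimated at 1500 nM, with a range of 300 nM to 8000 nM. That estimate means an expected step of a 13-fold higher number from compound 1 to compound 4 (1.10 log units; beyond the scatter).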

Compound 4, half-maximal effective concentration: 45600 nM
The estimate for compound 4 lay 30-fold (1.48 log units) below the measured number; the whole stated range lies below it.
By their numbers in this assay, from the lowest: compound 3; then compounds 1 and 2 (each within the scatter of the next); then compound 4.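

In this assay, within the data shown here, the carbonyl carbon proves even less tolerant than the earlier compounds showed: 4-(ethoxycarbonyl)phenoxy in place of (2-aminoethyl)amino gives a 380-fold higher number from compound 1 to compound 4 (2.58 log units; beyond the scatter), a larger step than a 21-fold lower number from compound 2 to compound 3 (1.32 log units; beyond the scatter) at the same kind of carbon. The new step was also taken with the (tert-butyl)carbonyl side chain, whereas the earlier one carried 1-hydroxy-2,2-dimethylpropyl. No measurement shown here explains the size of this step.

The compounds shown leave open whether the higher number goes with the oxygen link to the carbonyl carbon, the six-membered aromatic ring, the ethoxycarbonyl group or the loss of (2-aminoethyl)amino; a plain phenoxy group, a carboxylic acid in place of the ethoxycarbonyl, or an anilide would help separate these. Also open, from the compounds shown here alone, is how the same group behaves alongside 1-hydroxy-2,2-dimethylpropyl.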